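Thiophene sulfonamide piperazines: urea in place of thiourea

The source may report more compounds than this note shows. Statements on the series, on what has been measured and on what is new or still open speak of the compounds shown alone.

Measured so far:
- compound 1 `O=[N+]([O-])c1ccc(NC(=S)N2CCN(S(=O)(=O)c3sccc3-c3ccccc3Oc3ccc(O)c(O)c3)CC2)cc1`: 5300 nM
- compound 2 `O=C(NCCNS(=O)(=O)c1ccc(-c2ccccc2Oc2ccc([N+](=O)[O-])c([N+](=O)[O-])c2)s1)Nc1cc(Cl)cc(Cl)c1`: 2300 nM
- compound 3 `COc1ccc(Oc2ccccc2-c2ccsc2S(=O)(=O)N2CCN(C(=S)Nc3ccc([N+](=O)[O-])cc3)CC2)cc1OC`: > 50000 nM

In a functional assay on HL-60 cells (Homo sapiens) for inhibition, read by CCK-8 assay, with a stated time of 48 h (a lower number here means a stronger inhibitor, a higher number a weaker inhibitor), compound 1 gives 5300 nM, the highest of the two numbers given; compound 2 gives 2300 nM, a lower number beyond the scatter. For compound 3 this assay returns only a limit, > 50000 nM, so an at least 9.4-fold higher number from compound 1 to compound 3 (0.97 log units; beyond the scatter) cannot be sized further because of the limit of > 50000 nM in this assay, at which 1 of the 3 values shown sits.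

Compound 4 `O=C(Nc1ccc(F)cc1)N1CCN(S(=O)(=O)c2sccc2-c2ccccc2Oc2ccc(O)c(O)c2)CC1` follows from compound 1 by one change: a group of 10 heavy atoms (7 carbon, 1 nitrogen, 1 oxygen, 1 fluorine; one six-membered aromatic ring of carbon only) in place of a group of 12 heavy atoms (7 carbon, 2 nitrogen, 2 oxygen, 1 sulfur; one six-membered aromatic ring of carbon only), on an amine nitrogen in a ring

Within the data shown here, no measured step touches this position. Among the measured compounds shown here, the step to compound 3 concerns the dihydroxyphenyl on the aryl ether oxygen, which compound 4 keeps, and compound 2 differs in several places at once, so it gives no step. With nothing measured on the carbamoyl side, no step beyond the scatter is expected in this assay in either direction; the estimate for compound 4 therefore sits at a 1.1-fold higher number from compound 1 to compound 4 (0.05 log units; within the scatter) with a wide band.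

Compound 4 is estimated at 6000 nM, within 2000 nM to 20000 nM.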

Compound 4, half-maximal inhibitory concentration: 8100 nM
The estimate for compound 4 lay 1.4-fold (0.13 log units) below the measured number; the range from low to high includes it.
By their numbers in this assay, from the lowest: compound 2; then compounds 1 and 4 (each within the scatter of the next). At a limit, above all of these: compound 3.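

Placing (4-fluorophenyl)carbamoyl on the amine nitrogen in a ring of the core of compound 1 gives a 1.5-fold higher number from compound 1 to compound 4 (0.18 log units; within the scatter) in this assay, the only step shown at this position. With the 3,4-dihydroxyphenyl kept, this position therefore accepts the urea in place of the thiourea without a shift beyond the scatter, although the aryl group on that nitrogen changes in the same step, so the two parts of the change cannot be read apart and could offset each other. Nothing measured here gives a cause for this step.

A urea keeping the 4-nitrophenyl, or a thiourea carrying the 4-fluorophenyl, would separate the two parts of the change. Going by these compounds, how far the position tolerates other groups, such as a simple acetyl or a chain ending in a carboxylic acid, remains open.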